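A few compounds are considered here, and "the series" means these few. Any claim that something is new, unique, unknown or untested is made for them only; others in the source may bear on it.

Going by the values given here, compound 2 `COc1ccc(/C=N/NC(=O)Nc2ccc(Oc3ccnc(-c4nncn4CCN(C)C)c3)c(F)c2)c(OC)c1OC` gives 1790 nM in a functional assay on NCI-H460 cells (Homo sapiens) for cytotoxicity, read by MTT assay, with a stated time of 72 h (on this read-out higher numbers stand for weaker inhibition and lower numbers for stronger inhibition), the lowest of the two numbers known, with compound 1 `COc1ccc(OC)c(/C=N/NC(=O)Nc2ccc(Oc3ccnc(-c4nncn4CCN(C)C)c3)c(F)c2)c1` giving 2930 nM. Between them lies a 1.6-fold lower number from compound 1 to compound 2 (0.21 log units; within the scatter). Compound 3 `CN(C)CCn1cnnc1-c1cc(Oc2ccc(NC(=O)N/N=C/c3ccc(F)cc3)cc2F)ccn1` carries 4-fluorophenyl in place of 2,3,4-trimethoxyphenyl on a carbon with a double bond to nitrogen. Among the compounds with values here, the single measured step only swapped one methoxy pattern for another and stayed within the scatter; no measured step removes all methoxy groups or brings in a fluorine, so nothing here points to a change beyond the scatter. Compound 3 is therefore expected to show a 1.2-fold higher number from compound 2 to compound 3 (0.07 log units; within the scatter), an estimated 2100 nM in this assay, within a range of 600 nM to 7500 nM.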

Compound 3, half-maximal inhibitory concentration: 1980 nM
Compound 3: the middle estimate sits 1.1-fold (0.03 log units) above what was measured, and the stated range covers the measured number.
By their numbers in this assay, from the lowest: compounds 2, 3 and 1 (each within the scatter of the next).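

In this assay the position on a carbon with a double bond to nitrogen accepts 4-fluorophenyl in place of either methoxy-bearing ring, with a 1.1-fold higher number from compound 2 to compound 3 (0.04 log units; within the scatter) and with a 1.5-fold lower number from compound 1 to compound 3 (0.17 log units; within the scatter) and so no step outside the scatter. Unlike the earlier swap of one methoxy pattern for another, this change removes every methoxy group and brings in a fluorine, yet the three compounds still cannot be told apart. Nothing available explains this. As far as these compounds go, whether an amine or a carboxylic acid on that phenyl ring would move the number beyond the scatter stays open.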